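Methoxy to chloro, repeated on a second core

A few compounds are considered here, and "the series" means these few. Any claim that something is new, unique, unknown or untested is made for them only; others in the source may bear on it.

Of the compounds shown here, three have been tested in an assay for inhibition of acyl-CoA:cholesterol acyltransferase (Oryctolagus cuniculus), using microsomes; a lower number here means a stronger inhibitor, a higher number a weaker inhibitor. Compound 1 `COc1nc(C)cc(SC)c1NC(=O)N(Cc1ccc(Oc2ccc(F)cc2)cc1)C1CCCCCC1` gives 29 nM, compound 2 `CSc1cc(C)nc(Cl)c1NC(=O)N(Cc1ccc(Oc2ccc(F)cc2)cc1)C1CCCCCC1` gives 46 nM, and compound 3 `COc1nc(C)ccc1NC(=O)N(Cc1ccc(Oc2ccc(F)cc2)cc1)C1CCCCCC1` gives 39 nM. Compound 2 differs from compound 1 by chloro in place of methoxy on an aromatic carbon, and this change made a 1.6-fold higher number from compound 1 to compound 2 (0.20 log units; within the scatter). The core of compound 3 differs from the core of compound 1 by hydrogen in place of methylsulfanyl on an aromatic carbon. Compound 4 `Cc1ccc(NC(=O)N(Cc2ccc(Oc3ccc(F)cc3)cc2)C2CCCCCC2)c(Cl)n1`, not yet measured, differs from compound 3 by chloro in place of methoxy on an aromatic carbon. This is the same kind of change as that from compound 1 to compound 2, though the surroundings are not identical: in compound 1 the carbon is also meta to a methylsulfanyl group, which compound 3 lacks. The step from compound 3 to compound 4 in this assay is expected to be about a 1.5-fold higher number from compound 3 to compound 4 (0.19 log units; within the scatter), because the earlier change gave a 1.6-fold higher number from compound 1 to compound 2 (0.20 log units; within the scatter). Compound 4 is therefore estimated at 60 nM, most likely between 25 nM and 150 nM.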

Compound 4, half-maximal inhibitory concentration: 19 nM
Compound 4: the middle estimate sits 3.2-fold (0.50 log units) above what was measured; the measured number lies below the stated range.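

In this assay, chloro in place of methoxy does not carry over unchanged from one core to the other, and here it gives a 2.1-fold lower number from compound 3 to compound 4 (0.31 log units; beyond the scatter): the same change on two cores in this assay, a 1.6-fold higher number (0.20 log units; within the scatter) from compound 1 to compound 2 and a 2.1-fold lower number (0.31 log units; beyond the scatter) from compound 3 to compound 4, 3.3-fold (0.51 log units) apart, beyond the scatter of two such steps

Hydrogen in place of methylsulfanyl, which gives a 2.4-fold lower number from compound 2 to compound 4 (0.38 log units; beyond the scatter), also depends on what else the core carries: the same change on two cores in this assay, a 1.3-fold higher number (0.13 log units; within the scatter) from compound 1 to compound 3 and a 2.4-fold lower number (0.38 log units; beyond the scatter) from compound 2 to compound 4, 3.3-fold (0.51 log units) apart, beyond the scatter of two such steps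

The two changes are therefore not independent in these four compounds, but the numbers do not show why, and a 1.5-fold lower number from compound 1 to compound 4 (0.18 log units; within the scatter) spans both changes at once, so it separates neither.

The compounds shown leave open whether a bromo or an ethoxy group at the same place would follow the chloro result. They also leave open which of the two outcomes a further core would follow.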